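Nitro for methoxy on the benzoyl ring of a chalcone

The compounds below may be only part of what the source reports. "The series", "measured", "known", "first", "only" and "open" are said of these compounds alone.

Measured compounds:
compound 1, `COc1cccc(C(=O)/C=C/c2ccccc2)c1`, 8000 nM
compound 2, `O=C(/C=C/c1ccc(C(F)(F)F)cc1)c1ccccc1`, 14000 nM
compound 3, `O=C(/C=C/c1cccc([N+](=O)[O-])c1)c1ccccc1`, 2800 nM

In an ADME assay on A2780 cells (Homo sapiens) for inhibition, read by trypan blue exclusion, with a stated time of 72 h (on this read-out lower numbers stand for stronger inhibition of growth and higher numbers for weaker inhibition of growth), compound 1 gives the second highest of the three numbers. Compound 2 lies within the scatter of compound 1, so the two are not told apart. Compound 3 gives a lower number than compound 1, a gap beyond the scatter. Compound 4, `O=C(/C=C/c1ccccc1)c1cccc([N+](=O)[O-])c1`, has not been measured. It differs from compound 1 thus: nitro in place of methoxy on an aromatic carbon.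

Among the measured compounds shown here, with no measured step that matches this change, the expectation for compound 4 rests on the spread of the three numbers. The step from compound 1 to compound 4 is expected to be modest toward a lower number, a 2.3-fold lower number from compound 1 to compound 4 (0.36 log units; beyond the scatter). Compound 4 is therefore estimated at 3500 nM, with a range from 1200 nM to 10000 nM.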

Compound 4, concentration for 50% growth inhibition: 4300 nM
Compound 4: the middle estimate sits 1.2-fold (0.09 log units) below what was measured; the measured number falls inside the stated range.
By their numbers in this assay, from the lowest: compounds 3, 4, 1 and 2 (each within the scatter of the next, the first and the last beyond it).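

In this assay, nitro in place of methoxy on an aromatic carbon, meta to a large group, gives a 1.9-fold lower number from compound 1 to compound 4 (0.27 log units; within the scatter) and so the two groups are not told apart at this position. This first measured step at the position shows that exchanging these two groups leaves the read-out within its usual scatter. No evidence bears on a cause for this result. As far as these compounds go, whether an amine or a carboxylic acid on this carbon would read apart from methoxy and nitro stays open. So does how either group compares with plain hydrogen there.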